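From compound 2 to compound 3: one group changes

The source may hold more compounds than are shown below. What is called first, only, known or untested is meant among the compounds shown, and "the series" means these compounds.

Compound 1 `COc1cc(C(=O)c2cn(-c3ccccc3)cc2-c2ccccc2F)cc(OC)c1OC`: 30 nM
Compound 2 `COc1cc(C(=O)c2cn(-c3cccc(C)c3)cc2-c2ccccc2)cc(OC)c1OC`: 120 nM

In a functional assay on MCF7 cells (Homo sapiens) for inhibition, read by trypan blue exclusion, with a stated time of 3 days (on this read-out higher numbers stand for weaker inhibition and lower numbers for stronger inhibition), compound 2 gives 120 nM, the higher of the two numbers, and the gap down to compound 1 lies beyond the usual scatter. Compound 3 `COc1cc(C(=O)c2cn(-c3ccc(F)cc3)cc2-c2ccccc2)cc(OC)c1OC` has 4-fluorophenyl in place of 3-methylphenyl on an aromatic nitrogen. Among the measured compounds shown here, no measured pair shows this change alone, so the expectation stays close to compound 2 at 120 nM. In this assay a small move toward stronger inhibition, within the scatter, is expected: a 1.4-fold lower number from compound 2 to compound 3 (0.15 log units; within the scatter). For compound 3 the estimated value is 85 nM, with an expected range of 30 nM to 240 nM.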

Compound 3, half-maximal inhibitory concentration: 15 nM
Compound 3: the middle estimate sits 5.7-fold (0.75 log units) above what was measured; measured number below the stated range.
By their numbers in this assay, from the lowest: compounds 3 and 1 (each within the scatter of the next); then compound 2.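

In this assay the swap of 3-methylphenyl for 4-fluorophenyl on the aromatic nitrogen gives an 8.0-fold lower number from compound 2 to compound 3 (0.90 log units; beyond the scatter) with the heavy-atom count unchanged, so this position responds strongly to a small change. Compounds 1 and 2 differ in more than one place and could not show this. Nothing shown here explains the size of the step.

Going by these compounds, whether the gain comes from adding the fluorine, removing the methyl, or moving the substituent remains open. On these data alone, how 3-fluorophenyl, 4-methylphenyl or a group carrying an amine would behave on this nitrogen also remains open.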